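Purine riboside series: aryl-containing replacement for a cyclohexylsulfanyl group

The source may hold more compounds than are shown below. What is called first, only, known or untested is meant among the compounds shown, and "the series" means these compounds.

Compound 1 `OC[C@H]1O[C@@H](n2cnc3c(SC4CCCCC4)ncnc32)[C@H](O)[C@@H]1O` shows the lowest number of the three measured in an assay on isolated protein for binding affinity to Equilibrative nucleoside transporter 1 (Homo sapiens) (a higher number here means a weaker inhibitor, a lower number a stronger inhibitor), where compound 1 gives 6310 nM. Compound 2 `CCCSc1nc(N)nc2c1ncn2CC(C)C` gives 63100 nM in this assay, and compound 3 `CC(=O)c1ccccc1Sc1nc(N)nc2c1ncn2[C@@H]1O[C@H](CO)[C@@H](O)[C@H]1O` gives 447000 nM; both gaps to compound 1 lie beyond the scatter. Compound 4 `OC[C@H]1O[C@@H](n2cnc3c(CSc4ccc(I)cc4)ncnc32)[C@H](O)[C@@H]1O` is not yet measured. It differs from compound 1 as follows: a group of 9 heavy atoms (7 carbon, 1 sulfur, 1 iodine; one six-membered aromatic ring of carbon only) in place of a group of 7 heavy atoms (6 carbon, 1 sulfur; one six-membered non-aromatic ring of carbon only), on an aromatic carbon. For the measured compounds named here, no step between measured compounds in this assay is known, so the direction is uncertain; a moderate step toward a lower number is expected, with the full range leaving a step within the scatter possible. Compound 4 is estimated at 1500 nM, within 300 nM to 8000 nM, which would mean a step of a 4.2-fold lower number from compound 1 to compound 4 (0.62 log units; beyond the scatter).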

Compound 4, half-maximal inhibitory concentration: 69.2 nM
Compound 4: middle estimate off by 22-fold (1.34 log units), on the high side; measured number below the stated range.
By their numbers in this assay, from the lowest: compound 4; then compound 1; then compound 2; then compound 3.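

In this assay, the aromatic carbon carrying cyclohexylsulfanyl in compound 1 proves highly sensitive to its substituent: the iodine-bearing aromatic group gives a 91-fold lower number from compound 1 to compound 4 (1.96 log units; beyond the scatter) in a single change. For the compounds shown here, compound 2 and compound 3 differ from compound 1 in more than one place, so this pair gives the first direct reading at this position. No measurement shown bears on the cause of the step.

On these data alone, the change alters ring type, linkage and halogen together, so the part responsible stays open. As far as these compounds go, whether chlorine or a methoxy group could replace the iodine also stays open.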